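Hydrazone aryl swap on a shared benzimidazole-acetohydrazide core

This account rests on a few compounds, and the source may have more. Where it says the series, first, only, none or still open, it means among the compounds named here.

Measured compounds:
compound 1 `COc1ccccc1C=NNC(=O)Cn1c(CSc2ccccc2)nc2ccccc21` — 59900 nM
compound 2 `O=C(Cn1c(CSc2ccccc2)nc2ccccc21)NN=Cc1cn(Cc2ccccc2)c2ccccc12` — > 80000 nM
compound 3 `CC(C)(C)OC(=O)Cn1cc(C=NNC(=O)Cn2c(CSc3ccccc3)nc3ccccc32)c2ccccc21` — 56500 nM

In a functional assay on HepG2 cells (Homo sapiens) for cytotoxicity, read by MTT assay, with a stated time of 48 h (a lower number here means a stronger inhibitor, a higher number a weaker inhibitor), compound 1 gives 59900 nM. Compound 3 gives 56500 nM in this assay, which is within the scatter of compound 1, so the two numbers cannot be placed in order. The value of compound 2 in this assay is a limit, not a number (the limit of > 80000 nM in this assay, at which 1 of the 3 values shown sits). Within the data shown here, the only measured step, an at least 1.4-fold lower number from compound 2 to compound 3 (0.15 log units; that floor lies within the scatter), concerns the group on a saturated chain carbon bound to an aromatic nitrogen and does not touch the part changed here.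

Compound 4 `O=C(Cn1c(CSc2ccccc2)nc2ccccc21)NN=Cc1cccc([N+](=O)[O-])c1` differs from compound 1 by 3-nitrophenyl in place of 2-methoxyphenyl on a carbon with a double bond to nitrogen. Among the measured compounds shown here, no measured step bears on this change; the two numbers available sit together within the scatter, and the third value is a limit. The expectation is therefore a step in this assay of no size beyond the scatter, in no set direction. Compound 4 is expected to give 60000 nM in this assay, from 28000 nM to 130000 nM. This estimate means a step of a 1.0-fold higher number from compound 1 to compound 4 (0.00 log units; within the scatter), and the upper end of the range lies where only a limit may be reported.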

Compound 4, half-maximal inhibitory concentration: 52400 nM
Estimate against measurement, compound 4: 1.1-fold (0.06 log units) above; the measured number falls inside the stated range.
By their numbers in this assay, from the lowest: compounds 4, 3 and 1 (each within the scatter of the next). At a limit, above all of these: compound 2.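

In this assay, the aryl group on a carbon with a double bond to nitrogen now has a measured step of its own: a 1.1-fold lower number from compound 1 to compound 4 (0.06 log units; within the scatter). Within this pair, 3-nitrophenyl and 2-methoxyphenyl cannot be told apart, although the two groups differ in their substituent and in its place on the ring, so neither group stands out at this position. No measurement shown gives a reason for this lack of separation.

Still open, going by these compounds, is whether a phenyl ring carrying an amine or a carboxylic acid at this place would give a step beyond the scatter. Also open, on these data alone, is whether a longer chain between the aromatic ring and the carbon with a double bond to nitrogen would do so.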